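Compound 4: 2-hydroxypyridin-4-yl replaces 2,6-difluoropyridin-4-yl

This account rests on a few compounds, and the source may have more. Where it says the series, first, only, none or still open, it means among the compounds named here.

Three measured compounds share one core and differ only in the group attached to the five-membered aromatic ring with 1 nitrogen and 1 sulfur. Compound 1 `NS(=O)(=O)c1cccc(-c2nc(C(c3ccc(F)cc3)c3ccc(F)cc3)sc2CC(=O)O)c1` gives 710 nM in an in vitro functional assay on HEK285-7 cells for antagonist activity at prostaglandin D2 receptor 2 (Homo sapiens), read by BRET and beta-arrestin recruitment; on this read-out higher numbers stand for weaker inhibition and lower numbers for stronger inhibition. Compound 2 `CS(=O)(=O)Nc1cccc(-c2nc(C(c3ccc(F)cc3)c3ccc(F)cc3)sc2CC(=O)O)c1` gives 370 nM in this assay; the step of a 1.9-fold lower number from compound 1 to compound 2 (0.28 log units; within the scatter) stays within the scatter. Compound 3 `O=C(O)Cc1sc(C(c2ccc(F)cc2)c2ccc(F)cc2)nc1-c1cc(F)nc(F)c1` gives 110 nM in this assay and stands lowest of the three numbers: the steps of a 6.5-fold lower number from compound 1 to compound 3 (0.81 log units; beyond the scatter) and a 3.4-fold lower number from compound 2 to compound 3 (0.53 log units; beyond the scatter) are modest but beyond the scatter.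

Compound 4 `O=C(O)Cc1sc(C(c2ccc(F)cc2)c2ccc(F)cc2)nc1-c1ccnc(O)c1` has not been measured. The change from compound 3 is 2-hydroxypyridin-4-yl in place of 2,6-difluoropyridin-4-yl on an aromatic carbon. Going by the values given here, no measured step alters substituents on this six-membered aromatic ring; the two steps that bear on the position, a 6.5-fold lower number from compound 1 to compound 3 (0.81 log units; beyond the scatter) and a 3.4-fold lower number from compound 2 to compound 3 (0.53 log units; beyond the scatter), show only that exchanging the whole group at this carbon moves the number by a modest amount. Among the compounds with values here, with no direct precedent for 2-hydroxypyridin-4-yl, the expected step of a 2.5-fold higher number from compound 3 to compound 4 (0.41 log units; beyond the scatter) in this assay is a modest move upward, of the size seen for the earlier exchanges at this carbon. Compound 4 is therefore estimated at 280 nM in this assay, with a range from 80 nM to 1000 nM.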

Compound 4, half-maximal inhibitory concentration: 890 nM
Compound 4: the middle estimate sits 3.2-fold (0.50 log units) below what was measured; low and high end bracket the measured number.
By their numbers in this assay, from the lowest: compound 3; then compounds 2, 1 and 4 (each within the scatter of the next, the first and the last beyond it).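

In this assay, keeping the six-membered aromatic ring with 1 hetero atom at this carbon does not keep the number of compound 3: exchanging 2,6-difluoropyridin-4-yl for 2-hydroxypyridin-4-yl gives an 8.1-fold higher number from compound 3 to compound 4 (0.91 log units; beyond the scatter). The ring type alone therefore does not account for the lowest number in the series, which so far belongs only to the difluoro group of compound 3; compound 4 also stands apart from the methanesulfonamido compound, with a 2.4-fold higher number from compound 2 to compound 4 (0.38 log units; beyond the scatter), while it cannot be told from the sulfamoyl compound, with a 1.3-fold higher number from compound 1 to compound 4 (0.10 log units; within the scatter). Nothing on hand explains why the step from the difluoro to the hydroxy group has this size.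

The two fluorine atoms leave and the hydroxy group enters in a single step, so the compounds shown cannot separate the effect of removing fluorine from that of adding hydroxy. A ring with a single fluorine, or one with a methoxy group or an amine in place of the hydroxy group, would be needed to pull these contributions apart.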